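This account rests on a few compounds, and the source may have more. Where it says the series, first, only, none or still open, it means among the compounds named here.

Compound 1, with the structure `CCNC(=O)c1noc(-c2cc(C(C)C)c(O)cc2O)c1-c1cc(CNC(=O)CC)no1`, has no result in a functional assay on A2780 cells (Homo sapiens) for inhibition; a higher number here means a weaker inhibitor, a lower number a stronger inhibitor: its entry there reads "not determined" (no result reported), so no number for it is known and it cannot be placed on the scale that the other compounds occupy. Its nearest measured relative is compound 2, with the structure `CCNC(=O)c1noc(-c2cc(C(C)C)c(O)cc2O)c1-c1cc(CN2CCCC2)no1`, which in this assay gives 55 nM. The next compound is compound 3, with the structure `CCNC(=O)c1noc(-c2cc(C(C)C)c(O)cc2O)c1-c1cc(C(N)=O)no1`. It differs from compound 1 in one place: carbamoyl in place of (propanoylamino)methyl on an aromatic carbon. For the measured compounds named here, since compound 1 has no value, no measured step exists to lean on here. A change of this kind, carbamoyl in place of (propanoylamino)methyl on an aromatic carbon, is expected to move the inhibition of compound 3 toward the weaker side relative to compound 2, by an amount somewhat beyond the usual scatter, though a result within the scatter would not be surprising. For compound 3 in this assay the expected value is 200 nM, with a likely range from 40 nM to 1000 nM.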

Compound 3, half-maximal inhibitory concentration: 15 nM
Beside the measured number, compound 3's estimate is 13-fold (1.12 log units) above it; the measured number lies below the stated range.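

Going to carbamoyl in place of (pyrrolidin-1-yl)methyl gives a 3.7-fold lower number from compound 2 to compound 3 (0.56 log units; beyond the scatter) in this assay, so this change produces a stronger inhibitor. The position therefore does not depend on the (pyrrolidin-1-yl)methyl group for inhibition, and the number responds clearly to what sits on this aromatic carbon, although the step from compound 1 cannot be read, as compound 1 has no value. Nothing at hand explains why the number falls with this change.

Going by these compounds, it remains open whether the carbamoyl group itself matters or whether many small groups here would serve equally well. A carboxylic acid, a methyl ester, a methylcarbamoyl or a plain aminomethyl group at this place would help to separate those two readings.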